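The compounds below may be only part of what the source reports. "The series", "measured", "known", "first", "only" and "open" are said of these compounds alone.

Compound 3 `COc1ccc(/C=C2\CN(Cc3cn(Cc4ccc(F)cc4)nn3)C/C(=C\c3ccc(OC)cc3)C2=O)cc1` and compound 1 `COc1ccc(/C=C2\CN(Cc3cn(Cc4cccc(Cl)c4)nn3)C/C(=C\c3ccc(OC)cc3)C2=O)cc1` share one core, while compound 2 `O=C1/C(=C/c2ccccc2F)CN(C(=S)SCc2cn(Cc3ccc(F)cc3)nn2)C/C1=C\c1ccccc1F` is built on a different core; the difference between the two cores is not broken down here. In a functional assay on PC-3 cells (Homo sapiens) for cytotoxicity, read by MTT assay, with a stated time of 24 h (a higher number here means a weaker inhibitor, a lower number a stronger inhibitor), compound 3 gives 67500 nM. In the same this assay compound 1 gives 32500 nM. The step of a 2.1-fold lower number from compound 3 to compound 1 (0.32 log units; beyond the scatter) follows the change (3-chlorophenyl in place of 4-fluorophenyl on a saturated chain carbon bound to an aromatic nitrogen). For compound 2 the this assay returns only a limit, > 80000 nM, not a number. That limit, (the limit of > 80000 nM in this assay, at which 1 of the 3 values shown sits), is where compound 2 sits. Compound 4 `O=C1/C(=C/c2ccccc2F)CN(C(=S)SCc2cn(Cc3cccc(Cl)c3)nn2)C/C1=C\c1ccccc1F` has not yet been measured in this assay; it arises from compound 2 by 3-chlorophenyl in place of 4-fluorophenyl on a saturated chain carbon bound to an aromatic nitrogen, the same change that led from compound 3 to compound 1, at the same place. The measured guide for this change is the modest step of a 2.1-fold lower number from compound 3 to compound 1 (0.32 log units; beyond the scatter), and the limit for compound 2 leaves the starting point open. The step to compound 4 is expected to be an at least 1.3-fold lower number from compound 2 to compound 4 (0.12 log units; that floor lies within the scatter). Compound 4 is estimated at 60000 nM in the this assay, with a range from 25000 nM to 150000 nM, and a limit rather than a number remains quite possible.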

Compound 4, half-maximal inhibitory concentration: 80000 nM
Estimate against measurement, compound 4: 1.3-fold (0.12 log units) below; measured number inside the range.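

Compound 2 returns only a limit in this assay, > 80000 nM, and this limit is not a number. The change gives a number no higher from compound 2 to compound 4 (the limit leaves the size open), so the size of this step cannot be read. Set beside the step on the shared core of compound 3 and compound 1, the exchange of 4-fluorophenyl for 3-chlorophenyl therefore offers no second size for comparison: the same change on two cores in this assay, a 2.1-fold lower number (0.32 log units; beyond the scatter) from compound 3 to compound 1 and a number no higher (the limit leaves the size open) from compound 2 to compound 4; the limit leaves it open whether they differ. The result shows that the number did not rise on the core of compound 2, which agrees in direction with the earlier step, but it does not show that the change carries across the two cores with the same size, or that it lowers the number at all on the core of compound 2.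

The compounds shown leave open how 4-chlorobenzyl or 3-fluorobenzyl would read on either core. They also leave open how an unsubstituted benzyl, a longer chain such as phenethyl, or an amine would read at that place in this assay.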